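A few compounds are considered here, and "the series" means these few. Any claim that something is new, unique, unknown or untested is made for them only; others in the source may bear on it.

Compound 1 `CN(C)CCNc1ccnc2cc(OCc3ccc(F)cc3)ccc12`: 890 nM
Compound 2 `CN(C)CCNc1ccnc2cc(OCc3ccccc3)ccc12`: 1250 nM
Compound 3 `CCOc1ccc2c(NCCN(C)C)ccnc2c1`: 2520 nM

In a functional assay on BGC-823 cells (Homo sapiens) for cytotoxicity, read by MTT assay, with a stated time of 48 h (a lower number here means a stronger inhibitor, a higher number a weaker inhibitor), compound 1 gives the lowest of the three numbers. Compound 2 sits within the scatter of it, as a 1.4-fold higher number from compound 1 to compound 2 (0.15 log units; within the scatter) shows, while a 2.8-fold higher number from compound 1 to compound 3 (0.45 log units; beyond the scatter) is a modest step beyond the scatter. Compound 4 `Fc1ccc(COc2ccc3c(Cl)ccnc3c2)cc1` differs from compound 1 by chloro in place of (2-(dimethylamino)ethyl)amino on an aromatic carbon. Among the measured compounds shown here, none of the measured steps touches this change: a 1.4-fold higher number from compound 1 to compound 2 (0.15 log units; within the scatter) and a 2.0-fold higher number from compound 2 to compound 3 (0.30 log units; within the scatter) concern a different part of the shared core, so they give no guide to its size. The expectation therefore rests on compound 1 alone and carries wide uncertainty. Compound 4 is expected to give a higher number in this assay, estimated at 5000 nM with a range of 1500 nM to 20000 nM. The step of a 5.6-fold higher number from compound 1 to compound 4 (0.75 log units; beyond the scatter) is an estimate, not a measurement.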

Compound 4, half-maximal inhibitory concentration: 2780 nM
Compound 4: middle estimate off by 1.8-fold (0.25 log units), on the high side; the range from low to high includes it.
By their numbers in this assay, from the lowest: compounds 1, 2, 3 and 4 (each within the scatter of the next, the first and the last beyond it).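

Putting chloro in place of (2-(dimethylamino)ethyl)amino, on the carbon opposite the ring nitrogen, gives only a modest change in this assay: a 3.1-fold higher number from compound 1 to compound 4 (0.49 log units; beyond the scatter). The full chain at this position is therefore not needed for a measurable number, since compound 4, which carries a single chlorine atom there, still gives 2780 nM. No measurement given here explains the size of this step.

The compounds shown leave open how a longer chain ending in an amine, a simple amine, or a methoxy group would read at this position.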